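The source may report more compounds than this note shows. Statements on the series, on what has been measured and on what is new or still open speak of the compounds shown alone.

Measured compounds in a functional assay on OVCAR-4 cells (Homo sapiens) for antiproliferative activity, with a stated time of 48 h; a lower number here means that less compound is tolerated, a higher number that more compound is tolerated:
compound 1 `Cc1cc(O)c(C2=NN(c3ccc(S(N)(=O)=O)cc3)C(c3ccccc3O)C2)cc1Cl`: 51800 nM
compound 2 `Cc1cc(O)c(C2=NN(c3ccc(S(N)(=O)=O)cc3)C(c3ccccc3Cl)C2)cc1Cl`: 40000 nM
compound 3 `COc1ccc(C2CC(c3cc(Cl)c(C)cc3O)=NN2c2ccc(S(N)(=O)=O)cc2)cc1OC`: > 100000 nM

The value of compound 3 is a limit of this assay, not a number (the limit of > 100000 nM in this assay, at which 1 of the 3 values shown sits). Compound 4 `COc1ccc(C2CC(c3cc(Cl)c(C)cc3O)=NN2c2ccc(S(N)(=O)=O)cc2)c(OC)c1OC` differs from compound 3 by methoxy in place of hydrogen on an aromatic carbon. Going by the values given here, the steps that bear on this direction are those leading into compound 3: an at least 1.9-fold higher number from compound 1 to compound 3 (0.28 log units; that floor lies within the scatter) and an at least 2.5-fold higher number from compound 2 to compound 3 (0.39 log units; beyond the scatter). Both point toward a higher number, yet both end at the limit and therefore give only a floor. Since compound 3 already sits at the limit, no measurable movement is expected from a further methoxy; the estimated step is a step that the limit leaves unreadable from compound 3 to compound 4, none beyond the scatter. Compound 4 is therefore expected at 150000 nM, between 60000 nM and 400000 nM, and most likely reported again only as a limit.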

Compound 4, concentration lethal to 50% of the cells: > 100000 nM
Compound 4 gave a limit, no number; the forecaster's own chance of this, stated with the estimate: 80%; the middle value is on the limit's open side.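

In this assay compound 4 gives > 100000 nM as a limit of the assay and not a number, so methoxy on this aromatic carbon, ortho to a large group, does not return the series to a readable value. The 2,3,4-trimethoxyphenyl group shows an at least 2.5-fold higher number from compound 2 to compound 4 (0.39 log units; beyond the scatter) and an at least 1.9-fold higher number from compound 1 to compound 4 (0.28 log units; that floor lies within the scatter) as floors only. The step between compound 3 and compound 4 cannot be read, because both compounds sit at the limit: the limit of > 100000 nM in this assay, at which 2 of the 4 values shown sit.

From the compounds shown here alone, the direction and size of the effect of the added methoxy remain open. Also open, going by these compounds, is whether an amine or a carboxylic acid on this aromatic carbon would give a readable value.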